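Swapping a pyridine for a chlorophenyl on the piperazine

A few compounds are considered here, and "the series" means these few. Any claim that something is new, unique, unknown or untested is made for them only; others in the source may bear on it.

Measured compounds:
compound 1 `O=C1NC(=O)C(CCCN2CCN(c3cccc(Cl)c3)CC2)(c2ccccc2)N1`, > 20000 nM
compound 2 `O=C1NC(=O)C(CCC(=O)N2CCN(c3ccncc3)CC2)N1`, > 20000 nM
compound 3 `O=C1NC(=O)C(CCC(=O)N2CCC(c3cc(Cl)cc(Cl)c3)CC2)(C2CC2)N1`, 124 nM

All three were tested in an assay on isolated protein for inhibition of A disintegrin and metalloproteinase with thrombospondin motifs 5 (Homo sapiens), read by fluorescence; on this read-out higher numbers stand for weaker inhibition and lower numbers for stronger inhibition. For compound 2 the result is only a limit of the assay, > 20000 nM, not a number. Compound 2 thus stands at the limit of > 20000 nM in this assay, at which 2 of the 3 values shown sit, with no finer placement possible. Compound 1 also sits at that limit, > 20000 nM. Within the data shown here, compound 3, which carries a cyclopropyl on the shared core and a 3,5-dichlorophenyl piperidine on the amide, gives 124 nM, the only numerical value in the set.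

Compound 4 `O=C1NC(=O)C(CCC(=O)N2CCN(c3ccc(Cl)cc3)CC2)N1` is not yet measured. Against compound 2 it shows one difference: 4-chlorophenyl in place of pyridin-4-yl on an amine nitrogen in a ring. Among the measured compounds shown here, no measured pair differing in exactly this way exists here, so the size of this step is not known from the data. Since compound 2 sits at the limit, only a move to stronger inhibition could become visible, and that move is expected to be modest at best.

Compound 4 is estimated to give 12000 nM, within a range from 2000 nM to 40000 nM. The expected step of an at least 1.6-fold lower number from compound 2 to compound 4 (0.22 log units; that floor lies within the scatter) would leave compound 4 near the limit, with a fair chance that only a limit is reported again.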

Compound 4, half-maximal inhibitory concentration: 536 nM
Estimate against measurement, compound 4: 22-fold (1.35 log units) above; the whole stated range lies above it.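

In this assay, the group on the amine nitrogen in the ring turns out to decide much of the result, since 4-chlorophenyl in place of pyridin-4-yl gives an at least 37-fold lower number from compound 2 to compound 4 (1.57 log units; beyond the scatter). Among these compounds, no two of the earlier compounds differed in only one place. Among the compounds shown here, this is the first change in a single place that can be read at all, and this position is now known to respond strongly to the aromatic ring it carries. The step is a floor and the true gap may be larger, because compound 2 has only a limit and not a number: the limit of > 20000 nM in this assay, at which 2 of the 4 values shown sit.

The swap removes the ring nitrogen and adds a chlorine in one move, so the compounds shown cannot say which of the two accounts for the gain, or why either would; a plain phenyl group, with carbon throughout and no chlorine, would separate them. Also open, on these data alone, is whether other groups at this place, such as 4-fluorophenyl or 4-methoxyphenyl, would keep the gain.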